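The compounds below may be only part of what the source reports. "The series", "measured", "known", "first", "only" and "open" are said of these compounds alone.

Measured compounds:
Compound 1 `CC(C)(C)n1nc(Oc2cc(O)ccn2)c2c(N)ncnc21` gives 1.4 h in an ADME assay on microsomes from liver (Homo sapiens) for metabolic stability, read by LC-MS, using NADPH, with a stated time of 10 min, tested at 10 uM; a higher number here means that the compound lasts longer, a lower number that the compound disappears faster.
Compound 2 `Nc1ncnc2c1c(Oc1cccc(C(F)(F)F)c1)nn2[C@H]1C[C@H](O)C1` gives 1.25 h in this assay.
Compound 3 `Nc1ncnc2c1c(Oc1cc(C(F)(F)F)ccn1)nn2[C@H]1CC[C@@H](N)CC1` gives > 2.41 h in this assay.

Of these three, compound 3 stands apart from the other two in that its result is a limit of the assay rather than a number: compound 3 sits at the limit of > 2.41 h in this assay, at which 1 of the 3 values shown sits. Compound 1 and compound 2, the two with numbers, lie close to one another and within the usual scatter of each other, so nothing can be said about their order.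

Compound 4 `Nc1ncnc2c1c(Oc1cc(C(F)(F)F)ccn1)nn2C1CCC1` has not yet been measured in this assay. It differs from compound 3 in one place: cyclobutyl in place of 4-aminocyclohexyl on an aromatic nitrogen. For the measured compounds named here, no pair of measured compounds differing in one place exists here, so the step from compound 3 to compound 4 has no measured counterpart to lean on. What is known is that the two measured compounds carrying no amino group on the substituent at that aromatic nitrogen, compound 1 and compound 2, both gave numbers below the limit reached by compound 3.

On that basis compound 4 is expected to give a half-life of about 1.2 h, with a plausible range from 0.6 h to 2.41 h. The step of an at least 2.0-fold lower number from compound 3 to compound 4 (0.30 log units; that floor lies within the scatter) is thus estimated to run downward, beyond the scatter, although a result again at the limit cannot be ruled out.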

Compound 4, half-life: 1.02 h
Estimate against measurement, compound 4: 1.2-fold (0.07 log units) above; measured number inside the range.
By their numbers in this assay, from the lowest: compounds 4, 2 and 1 (each within the scatter of the next). At a limit, above all of these: compound 3.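

For the compounds shown here, with the rest of the molecule held constant, cyclobutyl in place of 4-aminocyclohexyl on an aromatic nitrogen gives an at least 2.3-fold lower number from compound 3 to compound 4 (0.37 log units; beyond the scatter) in this assay, and this is the first step here that changes one place only. Compound 3 carries a limit of the assay rather than a number, so the size of this step is a floor and not a measured distance: the limit of > 2.41 h in this assay, at which 1 of the 4 values shown sits. The pair shows that the group at this position can by itself move the half-life beyond the usual scatter, which compound 1 and compound 2 could not show, as each differs from compound 3 in more than one place.

The compounds shown leave open whether the difference follows the amine or the ring, as the step exchanges both at once, and how far the half-life of compound 3 lies past its limit also stays unknown. A plain cyclohexyl, or a cyclobutyl bearing an amine, at this position would separate the two.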